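The source may hold more compounds than are shown below. What is called first, only, known or untested is meant among the compounds shown, and "the series" means these compounds.

Measured in a functional assay on DU-145 cells (Homo sapiens) for cytotoxicity, read by MTT assay; on this read-out higher numbers stand for weaker inhibition and lower numbers for stronger inhibition:
Compound 1 `CC[C@@](C)(O)CC(=O)O[C@H](CC=C(C)C)C1=CC(=O)c2c(O)ccc(O)c2C1=O` gives 12700 nM.
Compound 2 `CC(C)=CC[C@@H](OC(=O)C1CCOC1)C1=CC(=O)c2c(O)ccc(O)c2C1=O` gives 47500 nM.
Compound 3 `CCCCC(C)(O)CC(=O)O[C@H](CC=C(C)C)C1=CC(=O)c2c(O)ccc(O)c2C1=O` gives 76500 nM.

Compound 2 holds the second highest of the three numbers. Its separation from compound 1, a 3.7-fold higher number from compound 1 to compound 2 (0.57 log units; beyond the scatter), is beyond the scatter, whereas a 1.6-fold higher number from compound 2 to compound 3 (0.21 log units; within the scatter) is within it, so compounds 2 and 3 cannot be ordered against each other.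

Compound 4 `CC(C)=CC[C@@H](OCC(C)O)C1=CC(=O)c2c(O)ccc(O)c2C1=O` is the next compound in the series. Relative to compound 2 it carries the change (2-hydroxypropyl in place of (oxolan-3-yl)carbonyl on an oxygen on a saturated carbon).

The measured steps of a 3.7-fold higher number from compound 1 to compound 2 (0.57 log units; beyond the scatter) and a 1.6-fold higher number from compound 2 to compound 3 (0.21 log units; within the scatter) each exchanged one group for another on the carbonyl carbon while keeping the carbonyl itself, and a 6.0-fold higher number from compound 1 to compound 3 (0.78 log units; beyond the scatter) altered only the chain on that carbonyl. None of them removed the carbonyl and set a chain bearing a hydroxyl directly on the oxygen, as happens here. Among the measured compounds shown here, no measured step therefore bears directly on this change, and no direction is supported; the estimate is centred on compound 2 with a wide range.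

Compound 4 is expected to give about 45000 nM, estimated between 12000 nM and 170000 nM. The step expected is a 1.1-fold lower number from compound 2 to compound 4 (0.02 log units; within the scatter).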

Compound 4, half-maximal inhibitory concentration: 16100 nM
Compound 4: middle estimate off by 2.8-fold (0.45 log units), on the high side; the measured number falls inside the stated range.
By their numbers in this assay, from the lowest: compounds 1 and 4 (each within the scatter of the next); then compounds 2 and 3 (each within the scatter of the next).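

In this assay, this position keeps its activity without the carbonyl: 2-hydroxypropyl on the oxygen gives a lower number than (oxolan-3-yl)carbonyl (a 3.0-fold lower number from compound 2 to compound 4 (0.47 log units; beyond the scatter)) and than (2-hydroxy-2-methylhexyl)carbonyl (a 4.8-fold lower number from compound 3 to compound 4 (0.68 log units; beyond the scatter)). Against (2-hydroxy-2-methylbutyl)carbonyl, the same change cannot be ordered (a 1.3-fold higher number from compound 1 to compound 4 (0.10 log units; within the scatter)), so a chain without a carbonyl matches the lowest-numbered ester shown, and the effect of removing the carbonyl depends on which acyl group leaves. No supporting data on the origin of these differences are available.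

The compounds shown do not separate the loss of the carbonyl from the arrival of the hydroxyl on the chain. A plain propyl or a 2-aminopropyl group on the same oxygen would address this open question.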